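Replacing 4-chlorophenyl with cyclohexyl in the series

The source may report more compounds than this note shows. Statements on the series, on what has been measured and on what is new or still open speak of the compounds shown alone.

Measured in an ADME assay on Vero cells (Chlorocebus sabaeus) for cytotoxicity, read by MTT assay, with a stated time of 96 h; on this read-out lower numbers stand for higher toxicity in this test and higher numbers for lower toxicity in this test:
- compound 1 `C/C(=N\NC(N)=S)c1ccc2[nH]c(-c3ccc(Cl)cc3)nc2c1`: > 100000 nM
- compound 2 `C/C(=N\NC(N)=S)c1ccc2c(c1)nc(-c1ccc(Cl)cc1)n2C1CCCCC1`: > 100000 nM

Compound 1 stands at > 100000 nM, which is a limit of the assay and not a number. Compound 2 gives > 100000 nM, again a limit. Within the data shown here, the series so far offers only this: the limit of > 100000 nM in this assay, at which 2 of the 2 values shown sit.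

The next compound is compound 3 `C/C(=N\NC(N)=S)c1ccc2[nH]c(C3CCCCC3)nc2c1`, whose difference from compound 1 is cyclohexyl in place of 4-chlorophenyl on an aromatic carbon. Among the measured compounds shown here, the one measured step, a step that the two limits leave unreadable from compound 1 to compound 2, bears on this only loosely. It places cyclohexyl on an aromatic nitrogen rather than in place of 4-chlorophenyl on an aromatic carbon, and its size cannot be read.

No step beyond the scatter is expected in this assay, on the strength of compound 1 with its limit of > 100000 nM. The estimated step is a number no higher from compound 1 to compound 3 (the limit leaves the size open). For compound 3 the estimated value is 100000 nM, with an expected range from 40000 nM to 200000 nM. A report as a limit is the likeliest outcome.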

Compound 3, half-maximal cytotoxic concentration: > 100000 nM
Compound 3 gave a limit, no number; the forecaster's own chance of this, stated with the estimate: 80%; the middle value lies on the limit itself.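

Compound 3 gives > 100000 nM in this assay, which is a limit of the assay and not a number. No step can be read from compound 1 to compound 3, as both values are limits: the limit of > 100000 nM in this assay, at which 3 of the 3 values shown sit.

The compounds shown leave open whether any change to the shared core gives a measurable half-maximal cytotoxic concentration in this assay.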